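An Aryl Swap on the Ring Nitrogen

The source may report more compounds than this note shows. Statements on the series, on what has been measured and on what is new or still open speak of the compounds shown alone.

Compound 2 `COc1cc(F)ccc1N1C(=O)CSC1c1cccc(C(=O)NCCCCc2ccccc2)c1` stands highest of the two compounds measured in a functional assay on HOS cells (Homo sapiens) for inhibition, read by CCK-8 assay, with a stated time of 72 h, tested at 1 uM; on this read-out higher numbers stand for more inhibition at the one concentration tested (going by the name of the read-out) and lower numbers for less inhibition: compound 2 gives 81%, while compound 1 `CCN1C(=O)CSC1c1cccc(C(=O)NCCCCc2ccccc2)c1` gives 6%. Within the data shown here, the single measured step, a number 75 percentage points higher from compound 1 to compound 2 (beyond the scatter), came with 4-fluoro-2-methoxyphenyl in place of ethyl on an amide-type nitrogen in a ring. Compound 3 `O=C(NCCCCc1ccccc1)c1cccc(C2SCC(=O)N2c2cccc(F)c2)c1` has not yet been measured. It differs from compound 2 in one place: 3-fluorophenyl in place of 4-fluoro-2-methoxyphenyl on an amide-type nitrogen in a ring. Among the measured compounds shown here, the measured step bears on this change only in part, since it shows that an aryl group on this nitrogen, set against ethyl, went with a large rise, but no measured pair shows what the methoxy group alone contributes. Because compound 2 reached 81% with an aryl group on this nitrogen, compound 3, which keeps an aryl group there, is expected to retain much of that inhibition, and the step is estimated at a number 26 percentage points lower from compound 2 to compound 3 (beyond the scatter) in this assay, a moderate drop to cover the uncertainty. For compound 3 the estimate is 55%, with a range from 20% to 85%.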

Compound 3, a percentage reported as inhibition, at one concentration (the size of the read-out at that concentration, not a potency): 84%
Estimate against measurement, compound 3: 29 percentage points below; the range from low to high includes it.
By their numbers in this assay, from the lowest: compound 1; then compounds 2 and 3 (each within the scatter of the next).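

In this assay the change on the ring nitrogen gave a number 3 percentage points higher from compound 2 to compound 3 (within the scatter), so the two aryl groups cannot be told apart here, and the methoxy group of compound 2 is not required for this level of inhibition at the one concentration tested; the step cannot isolate the methoxy group, however, since the fluorine also differs between 4-fluoro-2-methoxyphenyl and 3-fluorophenyl. The comparison with the ethyl compound gave a number 78 percentage points higher from compound 1 to compound 3 (beyond the scatter), so the large rise over ethyl no longer rests on a single aryl group but holds for both substituted phenyl groups shown at this position. Nothing available here accounts for the rise over ethyl or for the level read-out of the two aryl compounds.

On these data alone, what a plain phenyl, a cyclohexyl or a benzyl group would give on this nitrogen remains open, and with it whether the fluorine is needed at all. As far as these compounds go, since compound 2 and compound 3 are compared at a single concentration, any difference in potency between them also remains open.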